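The compounds below may be only part of what the source reports. "The series", "measured", "known", "first", "only" and "open" are said of these compounds alone.

Compound 1 `C[C@@H](O[C@H]1CN2C(=O)C=C(c3ccccc3)CC2[C@@H]1c1ccc(F)cc1)c1cc(C(F)(F)F)cc(C(F)(F)F)c1` is the reference point here. In an assay on CHO cells for displacement of a labelled ligand from Substance-P receptor (Homo sapiens), in the presence of a further agent that is not named here (on this read-out higher numbers stand for weaker inhibition and lower numbers for stronger inhibition), compound 1 gives 89.5 nM, and compound 2 `C[C@@H](O[C@H]1CN2C(=O)C=C(c3ccc(F)cc3)CC2[C@@H]1c1ccc(F)cc1)c1cc(C(F)(F)F)cc(C(F)(F)F)c1`, with fluoro in place of hydrogen on an aromatic carbon, gives 100 nM; the two are separated only by a 1.1-fold higher number from compound 1 to compound 2 (0.05 log units; within the scatter), so neither stands apart from the other. Compound 3 `C[C@@H](O[C@H]1CN2C(=O)C=C(c3cnn(Cc4ccccc4)c3)CC2[C@@H]1c1ccc(F)cc1)c1cc(C(F)(F)F)cc(C(F)(F)F)c1` has not yet been measured. Its change from compound 1 is 1-benzyl-1H-pyrazol-4-yl in place of phenyl on a double-bonded ring carbon. Within the data shown here, no measured step matches this change: the one step in hand, a 1.1-fold higher number from compound 1 to compound 2 (0.05 log units; within the scatter), is a small alteration on the same ring and stayed within the scatter, so it offers little guidance for a larger replacement. With nothing else to build on, compound 3 is expected to land near compound 1 with a wide band of uncertainty. The estimated step is a 1.7-fold higher number from compound 1 to compound 3 (0.22 log units; within the scatter). For compound 3 the expected value is 150 nM, between 30 nM and 800 nM.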

Compound 3, half-maximal inhibitory concentration: 66 nM
The estimate for compound 3 lay 2.3-fold (0.36 log units) above the measured number; the measured number falls inside the stated range.
By their numbers in this assay, from the lowest: compounds 3, 1 and 2 (each within the scatter of the next).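

In this assay the double-bonded ring carbon accepts a far larger replacement than the earlier fluoro: 1-benzyl-1H-pyrazol-4-yl, which brings in a five-membered aromatic ring with 2 hetero atoms as well as a further six-membered aromatic ring, gives a 1.4-fold lower number from compound 1 to compound 3 (0.13 log units; within the scatter) when it takes the place of phenyl. In place of 4-fluorophenyl the same group gives a 1.5-fold lower number from compound 2 to compound 3 (0.18 log units; within the scatter) and so stays within the scatter here too, which means that the added size and the 2 hydrogen-bond acceptors leave the read-out unmoved in this pair of steps. Nothing at hand bears on what lies behind this result.

The compounds shown leave open whether the benzyl on the pyrazole matters at all, as a plain 1-methyl-1H-pyrazol-4-yl would show. They also leave open whether this carbon would accept a group carrying an amine or a carboxylic acid.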